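A ring replaces methoxy on the chain of compound 3

The compounds below may be only part of what the source reports. "The series", "measured", "known", "first", "only" and "open" are said of these compounds alone.

Measured in an ADME assay on S9 fraction from liver (Homo sapiens) for metabolic stability, with a stated time of 60 min; on this read-out higher numbers stand for a more stable compound and lower numbers for a less stable compound:
- compound 1 `Cc1nc(-c2nc[nH]n2)ccc1-c1cnc2c(n1)N([C@H]1CC[C@@H](O)CC1)C(=O)CN2`: 100%
- compound 2 `CO[C@H]1CC[C@@H](CN2C(=O)CNc3ncc(-c4ccc(-c5nc[nH]n5)nc4C)nc32)CC1`: 10%
- compound 3 `COCCN1C(=O)CNc2ncc(-c3ccc(-c4nc[nH]n4)nc3C)nc21`: 100%

Compound 3 sits level with compound 1, as the comparison gives no change at the digits printed from compound 1 to compound 3 (within the scatter). Compound 2 stands well apart, with a number 90 percentage points higher from compound 2 to compound 3 (beyond the scatter).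

Compound 4 `Cc1nc(-c2nc[nH]n2)ccc1-c1cnc2c(n1)N(CCC1CCOCC1)C(=O)CN2` is compound 3 with a single change: oxan-4-yl in place of methoxy on a saturated chain carbon, two bonds along the chain from an amide-type nitrogen in a ring.

All three measured steps concern the group on that same nitrogen, and two of them pull in different directions. Compound 2, like compound 4, carries a six-membered non-aromatic ring on a chain from that nitrogen, and the data show a number 90 percentage points lower from compound 1 to compound 2 (beyond the scatter). Compound 1 also carries a six-membered non-aromatic ring, directly on the nitrogen, yet it gives 100%. A ring alone therefore does not settle the outcome, and three compounds cannot show what does. The closer resemblance to compound 2 points downward, but compound 4 shares neither the methoxy nor the cyclohexyl ring of compound 2, so only part of that large step is expected.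

The expected step is a number 35 percentage points lower from compound 3 to compound 4 (beyond the scatter), a moderate one with wide uncertainty. Compound 4 is estimated at 65%, with an expected range from 25% to 100%.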

Compound 4, percent of the compound remaining: 100%
For compound 4 the middle estimate is 35 percentage points below the measured one, and the stated range covers the measured number.
By their numbers in this assay, from the lowest: compound 2; then compounds 1, 3 and 4 (each within the scatter of the next).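

Swapping methoxy for oxan-4-yl at this chain position gives no change at the digits printed from compound 3 to compound 4 (within the scatter) in this assay, so a six-membered non-aromatic ring with one hetero atom is tolerated here, although it is much larger than the group it replaces. Compound 4 also shows no change at the digits printed from compound 1 to compound 4 (within the scatter), and the comparison with the other chain-linked ring shows a number 90 percentage points higher from compound 2 to compound 4 (beyond the scatter), so a six-membered ring reached through a chain does not by itself go with the low number of compound 2. Among these four compounds, only compound 2 stands apart, while compounds 1, 3 and 4 lie within the scatter of one another.

Nothing here explains these numbers, and it remains open which difference between compound 2 and compound 4 matters: the methoxy, the all-carbon ring or the chain length. From the compounds shown here alone, it is also open how the read-out would respond to an amine or a carboxylic acid on this chain, or to a longer chain carrying the oxan-4-yl ring.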